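A few compounds are considered here, and "the series" means these few. Any claim that something is new, unique, unknown or untested is made for them only; others in the source may bear on it.

Measured in a functional assay (BAEC cells, Bos taurus) for inhibition, read by cell counting, with a stated time of 3 days; on this read-out lower numbers stand for stronger inhibition and higher numbers for weaker inhibition:
- compound 1 `COc1ccc(N(C)c2nc(C)nc3c2nc(C)n3C)cc1` gives 7400 nM
- compound 2 `COc1ccc(Nc2nc(C)nc3c2nc(C)n3C)cc1` gives >= 100000 nM (a limit)
- compound 3 `COc1cccc(N(C)c2nc(C)nc3c2nc(C)n3C)c1` gives >= 100000 nM (a limit)

Going by the values given here, compound 1 holds the only actual number in the set, as the other two values are limits. Compound 3 differs from compound 1 only in where the methoxy sits.

Next is compound 4 `Cc1ccc(N(C)c2nc(C)nc3c2nc(C)n3C)cc1`, with the change (methyl in place of methoxy on an aromatic carbon), methyl in place of methoxy on an aromatic carbon.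

Among the compounds with values here, no measured step covers this exchange. Within the data shown here, the one measured step, an at least 13-fold higher number from compound 1 to compound 2 (1.13 log units; beyond the scatter), lies at a nitrogen and bears only indirectly, showing that one small change to compound 1 can move the number far. A moderate move towards weaker inhibition, beyond the scatter, is therefore expected, and the values leave that size uncertain. The expected shift is a 2.7-fold higher number from compound 1 to compound 4 (0.43 log units; beyond the scatter). Compound 4 could also reach (the limit of >= 100000 nM in this assay, at which 2 of the 3 values shown sit).

For compound 4 the estimated value is 20000 nM, with an expected range of 5000 nM to 100000 nM.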

Compound 4, half-maximal inhibitory concentration: > 100000 nM
Compound 4 was reported as a limit; the forecaster's own chance of this, stated with the estimate: 35%; middle value at least 5.0-fold (0.69 log units) from the limit.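

In this assay, the methoxy on the aromatic carbon para to a large group proves to be more than a replaceable substituent: methyl in its place gives an at least 13-fold higher number from compound 1 to compound 4 (1.13 log units; beyond the scatter). Compound 4 gives > 100000 nM, which is a limit and not a number, so this step sets only a minimum size for the change. Compound 1 now stands alone as the only compound with an actual number, since all three single changes shown, at the nitrogen, in the methoxy position and now in the methoxy itself, end at a limit: the limit of > 100000 nM in this assay, at which 1 of the 4 values shown sits.

On these data alone, it remains open how a hydroxyl, an ethoxy or an amine at this same carbon would read, and whether any of them would improve on compound 1 at 7400 nM. As far as these compounds go, the methyl groups on the shared core also remain open, as no change to them appears here.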